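Replacing the thiazolyl-ethenyl group with methoxyphenyl

The source may report more compounds than this note shows. Statements on the series, on what has been measured and on what is new or still open speak of the compounds shown alone.

Compound 1, `COC(=O)/C=C/c1cccc(N(Cc2ccc(/C=C/c3cccc(C(F)(F)F)c3)cc2)C(=O)C(C)C)c1`, in an assay on isolated protein with Bile acid receptor (Homo sapiens) as the target (a higher number here means that more compound is needed for the effect, a lower number that less compound is needed), gives 267 nM.
Compound 2, `COC(=O)/C=C/c1cccc(N(Cc2ccc(/C=C/c3cccc(F)c3)cc2)C(=O)C(C)C)c1`, in this assay gives 71 nM.
Compound 3, `COC(=O)/C=C/c1cccc(N(Cc2ccc(/C=C/c3scnc3C)cc2)C(=O)C(C)C)c1`, in this assay gives 228 nM.

All three compounds share one core and differ only in the group at the far end of the ethenyl chain. Compound 3 stands second highest of the three numbers: the step of a 1.2-fold lower number from compound 1 to compound 3 (0.07 log units; within the scatter) lies within the scatter, whereas the step of a 3.2-fold higher number from compound 2 to compound 3 (0.51 log units; beyond the scatter) lies beyond it.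

Compound 4, `COC(=O)/C=C/c1cccc(N(Cc2ccc(-c3ccc(OC)cc3)cc2)C(=O)C(C)C)c1`, is not yet measured. It differs from compound 3 by 4-methoxyphenyl in place of 2-(4-methyl-1,3-thiazol-5-yl)ethenyl on an aromatic carbon. The ethenyl linker is thus gone as well, and the new ring is joined directly to the core.

The measured steps all change the group at the end of the chain while keeping the chain. They are modest: a 3.8-fold lower number from compound 1 to compound 2 (0.58 log units; beyond the scatter), a 3.2-fold higher number from compound 2 to compound 3 (0.51 log units; beyond the scatter), and the small 1.2-fold lower number from compound 1 to compound 3 (0.07 log units; within the scatter). No measured step removes the chain itself, so the present change has no direct precedent among these compounds. Given that the three variations at this end span only a modest range, compound 4 is expected to land in a similar region, with the step of a 1.1-fold lower number from compound 3 to compound 4 (0.06 log units; within the scatter) estimated to be near the scatter and its direction uncertain. Compound 4 is therefore estimated at 200 nM in this assay, with a range from 60 nM to 700 nM.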

Compound 4, half-maximal effective concentration: 97 nM
The estimate for compound 4 lay 2.1-fold (0.31 log units) above the measured number; measured number inside the range.
By their numbers in this assay, from the lowest: compounds 2 and 4 (each within the scatter of the next); then compounds 3 and 1 (each within the scatter of the next).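

The ethenyl chain is not required for a number in this range in this assay: with a 4-methoxyphenyl ring joined directly to the shared core, the data show a 2.4-fold lower number from compound 3 to compound 4 (0.37 log units; beyond the scatter) and a 2.8-fold lower number from compound 1 to compound 4 (0.44 log units; beyond the scatter), both modest steps beyond the scatter. The third comparison, a 1.4-fold higher number from compound 2 to compound 4 (0.14 log units; within the scatter), lies within the scatter, so the directly joined ring and the 2-(3-fluorophenyl)ethenyl group cannot be told apart here, even though they differ in the double bond outside the aromatic rings. No supporting data accompany these results to explain the steps, and the ring and the linker changed together, so the share of each in a step remains unknown.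

The compounds shown leave open what the 4-methoxyphenyl ring would give when carried on the ethenyl chain, and what the 3-fluorophenyl ring would give when joined directly to the core. Also open, from the compounds shown here alone, is how a directly joined ring would behave with an amine or a carboxylic acid in place of its methoxy group.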